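The compounds below may be only part of what the source reports. "The series", "measured", "known", "first", "only" and "open" are said of these compounds alone.

Measured so far in a physicochemical assay for solubility, measured as kinetic solubility; on this read-out lower numbers stand for lower solubility and higher numbers for higher solubility:
compound 1 `COC(c1cc(Cl)c2c(c1Cl)C(=O)N(Cc1c(C)cc(C)[nH]c1=O)CC2)C1CCOC1`: 415000 nM; 457000 nM; 439000 nM; 436000 nM (4 entries)
compound 2 `Cc1cc(C)c(CN2CCc3c(Cl)cc([C@@H](CO)[C@@H]4CCOC4)c(Cl)c3C2=O)c(=O)[nH]1`: 537000 nM
compound 3 `Cc1cc(C)c(CN2CCc3c(Cl)cc(C(CO)C4CCOC4)c(Cl)c3C2=O)c(=O)[nH]1`: 522000 nM; 508000 nM (2 entries)

Compound 2 stands on a single entry of 537000 nM, while the other two compounds were read more than once: the several entries of compound 1 in this assay, 415000 nM; 457000 nM; 439000 nM; 436000 nM (4 entries), and (the several entries of compound 3 in this assay, 522000 nM; 508000 nM (2 entries)). All three values lie within the usual scatter of one another, so compound 2 holds no separate place among them. Any comparison of the closest pair must also bear in mind (the fact that one of compounds 2 and 3 is drawn with a defined configuration and the other without, at the place where they differ).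

Compound 4 `Cc1cc(C)c(CN2CCc3c(Cl)cc([C@@H](CO)[C@@H]4CCCO4)c(Cl)c3C2=O)c(=O)[nH]1` has not yet been measured. It has the same atoms as compound 2, joined differently: oxolan-2-yl in place of oxolan-3-yl on a saturated chain carbon bound to an aromatic carbon and a saturated chain carbon.

For the measured compounds named here, no measured pair isolates this change, so the expectation rests only on the narrow spread of the measured compounds, with compound 1 at 415000 nM; 457000 nM; 439000 nM; 436000 nM (4 entries) and compound 3 at 522000 nM; 508000 nM (2 entries). No step beyond the scatter is expected in this assay, in either direction. The expected change is a 1.1-fold lower number from compound 2 to compound 4 (0.03 log units; within the scatter). For compound 4 the estimated value is 500000 nM, with an expected range of 300000 nM to 700000 nM.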

Compound 4, solubility: 550000 nM
Beside the measured number, compound 4's estimate is 1.1-fold (0.04 log units) below it; the measured number falls inside the stated range.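

In this assay, setting oxolan-2-yl in place of oxolan-3-yl on a saturated chain carbon bound to an aromatic carbon and a saturated chain carbon gives a 1.0-fold higher number from compound 2 to compound 4 (0.01 log units; within the scatter) and so leaves the read-out unmoved. The earlier compounds shown here offered no step that isolated the group at this place, and this one shows that the read-out does not separate these two ring attachments when the atoms stay the same. The information available gives no reason for this result.

Going by these compounds, what remains open is whether a group of a different kind at this place, such as an amine or a carboxylic acid in place of the oxolane ring, would move the read-out beyond the scatter. Also open, on these data alone, is how the opposite configuration at the defined stereocentre of the oxolan-2-yl ring would read.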